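The source may report more compounds than this note shows. Statements on the series, on what has been measured and on what is new or still open speak of the compounds shown alone.

Compound 1 `COc1ccc(/C=N/NC(=N)NO)cc1` is a limit of the assay: in a functional assay on HL-60 cells (Homo sapiens) for antiproliferative activity (on this read-out higher numbers stand for weaker inhibition and lower numbers for stronger inhibition), compound 1 gives > 100000 nM.
Compound 2 `Cc1ccccc1/C=N/NC(=N)NO` is likewise a limit: in this assay compound 2 gives > 100000 nM.

Compound 2 thus stands at the assay ceiling, with no number of its own. Both values shown share that position, as the limit of > 100000 nM in this assay, at which 2 of the 2 values shown sit, records. Compound 3 `N=C(NO)N/N=C/c1ccccc1` differs from compound 2 by hydrogen in place of methyl on an aromatic carbon. Within the data shown here, no step between measured compounds exists here, so the expected change in this assay is none beyond the scatter, and the estimated step that the limit leaves unreadable from compound 2 to compound 3 reflects that. Compound 3 is therefore expected near 150000 nM, within 50000 nM to 500000 nM, most likely again reported only as a limit.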

Compound 3, half-maximal inhibitory concentration: 62000 nM
The estimate for compound 3 lay 2.4-fold (0.38 log units) above the measured number; measured number inside the range.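

Among these compounds, compound 3, which carries hydrogen on the aromatic carbon, is the only one of the three compounds to give a number rather than a limit in this assay. Hydrogen in place of methyl yields an at least 1.6-fold lower number from compound 2 to compound 3 (0.20 log units; that floor lies within the scatter) and hydrogen in place of methoxy yields an at least 1.6-fold lower number from compound 1 to compound 3 (0.20 log units; that floor lies within the scatter). Each step is only a floor, and its true size stays unreadable because the other two compounds sit at a limit: the limit of > 100000 nM in this assay, at which 2 of the 3 values shown sit.

As far as these compounds go, how an amine or a carboxylic acid on that aromatic carbon would read in this assay remains open.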